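This account rests on a few compounds, and the source may have more. Where it says the series, first, only, none or still open, it means among the compounds named here.

Measured so far:
compound 1, `Cc1ccc(-n2nccn2)c(C(=O)N2CC3(CC3)C[C@H]2CNc2ccc(Cl)cn2)c1`, which in a functional assay on CHO cells for antagonist activity at Orexin/Hypocretin receptor type 1 (Homo sapiens), read by FLIPR and calcium flux (a lower number here means a less potent compound, a higher number a more potent compound, by a factor of ten per unit of this negative logarithm), gives 8.1;
compound 2, `Cc1nc(C(=O)N2CC3(CC3)C[C@H]2CNc2cc(C(F)(F)F)ccn2)c(-c2ccccc2)s1`, which in this assay gives 8.2;
compound 3, `Cc1ccc(-c2ncccn2)c(C(=O)N2CCC3(CC3)C[C@H]2CNc2ccc(Cl)cn2)c1`, which in this assay gives 7.6.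

Compound 2 has the highest of these three numbers, but compound 1 lies within the scatter of it, so the two cannot be told apart; only compound 3 sits beyond the scatter. Compound 4, `Cc1nc(C(=O)N2CC3(CC3)C[C@H]2CNc2ccc(C(F)(F)F)cn2)c(-c2ccccc2)s1`, has not been measured. It differs from compound 2 by 5-(trifluoromethyl)pyridin-2-yl in place of 4-(trifluoromethyl)pyridin-2-yl on an amine nitrogen. Within the data shown here, no measured pair shows this change, so it is judged on its own: the expected step from compound 2 to compound 4 in this assay is no change at the digits printed from compound 2 to compound 4 (within the scatter), none beyond the scatter, in either direction. Compound 4 is therefore expected to give about 8.2, within a range from 7.6 to 8.7.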

Compound 4, negative logarithm of the antagonist equilibrium constant: 8.4
Compound 4: the middle estimate sits 0.20 log units below what was measured, within the range that was stated.
By their numbers in this assay, from the lowest: compound 3; then compounds 1, 2 and 4 (each within the scatter of the next).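

In this assay, 5-(trifluoromethyl)pyridin-2-yl in place of 4-(trifluoromethyl)pyridin-2-yl on the amine nitrogen gives a number 0.20 log units higher from compound 2 to compound 4 (within the scatter) and so the two placements of the trifluoromethyl group cannot be told apart. Among these compounds, this is the first pair that differs in one place only, since the earlier compounds differed from one another in several. Nothing measured here offers an explanation for this result. On these data alone, whether a nitrile or a methoxy group in place of trifluoromethyl on this pyridine would keep the number stays open, as does whether the same change reads alike with the amide part of compound 1.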